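This account rests on a few compounds, and the source may have more. Where it says the series, first, only, none or still open, it means among the compounds named here.

Measured so far (in a functional assay on OVCAR-5 cells (Homo sapiens) for inhibition, read by CCK-8 assay, with a stated time of 72 h, tested at 1 uM; a higher number here means more inhibition of growth at the concentration tested, a lower number less inhibition of growth)
- compound 1 `CN(C)C(=O)c1cc2cnc(Nc3ccc(NC(=O)C4(C(=O)Nc5cccc(O)c5)CC4)cc3)nc2n1C1CCCC1` gives 58.5%
- compound 2 `CN(C)C(=O)c1cc2cnc(Nc3ccc(NC(=O)C4(C(=O)Nc5ccc(Br)cc5)CC4)cc3)nc2n1C1CCCC1` gives 13.7%
- compound 3 `CN(C)C(=O)c1cc2cnc(Nc3ccc(NC(=O)C4(C(=O)Nc5cccc(Br)c5)CC4)cc3)nc2n1C1CCCC1` gives 0.04%

Compound 3 stands lowest of the three, with compound 2 and compound 1 both higher beyond the scatter. Compound 4 `CN(C)C(=O)c1cc2cnc(Nc3ccc(NC(=O)C4(C(=O)Nc5ccc(O)cc5)CC4)cc3)nc2n1C1CCCC1` is still unmeasured. The change from compound 3 is 4-hydroxyphenyl in place of 3-bromophenyl on an amide-type nitrogen.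

Among the compounds with values here, three measured steps bear on this change. The exchange of hydroxy for bromo on an aromatic carbon is large (a number 58.5 percentage points lower from compound 1 to compound 3 (beyond the scatter)) and runs opposite to the change made here. The exchange of the 4-bromophenyl for the 3-bromophenyl is modest (a number 13.7 percentage points lower from compound 2 to compound 3 (beyond the scatter)) and also runs opposite. The remaining step combines both kinds of difference and is large (a number 44.8 percentage points lower from compound 1 to compound 2 (beyond the scatter)). Within the data shown here, no measured pair compares 4-hydroxyphenyl with 3-hydroxyphenyl, so the hydroxy result carries over to the new place only with uncertainty.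

Reading the first two steps backwards, a large upward step is expected (a number 55 percentage points higher from compound 3 to compound 4 (beyond the scatter)) in this assay for this change. For compound 4 the estimated value is 55% (expected range 25% to 80%).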

Compound 4, percent growth inhibition at one concentration: 80.7%
Beside the measured number, compound 4's estimate is 25.7 percentage points below it; the measured number lies above the stated range.
By their numbers in this assay, from the lowest: compound 3; then compound 2; then compound 1; then compound 4.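

In this assay, within the data shown here, the earlier compounds left open whether the place of the hydroxy on the phenyl ring matters, and it does: 4-hydroxyphenyl on the amide-type nitrogen gives a modest gain over 3-hydroxyphenyl, a number 22.2 percentage points higher from compound 1 to compound 4 (beyond the scatter), which makes compound 4 the highest of the four. The complete change gives a number 80.7 percentage points higher from compound 3 to compound 4 (beyond the scatter), while hydroxy in place of bromo with the ring place held gives a number 67 percentage points higher from compound 2 to compound 4 (beyond the scatter), so most of the complete change follows the exchange of bromo for hydroxy rather than the shift of ring place. The exchange now stands as a repeated result, with a similar size in the 3-substituted and 4-substituted pairs: the same change on two cores in this assay, a number 58.5 percentage points lower (beyond the scatter) from compound 1 to compound 3 and a number 67 percentage points lower (beyond the scatter) from compound 4 to compound 2, 8.5 percentage points apart, within the scatter of two such steps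

Whether hydroxy is specifically required remains open, as the compounds shown compare it only with bromo and offer no reading for an unsubstituted phenyl, methoxy, an amine or a carboxylic acid at these ring places. From the compounds shown here alone, the read-out is also taken at a single concentration, so it remains open whether this order of the four compounds would hold at other concentrations.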